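The source may report more compounds than this note shows. Statements on the series, on what has been measured and on what is new or still open speak of the compounds shown alone.

Compound 3 `COc1cc2c(Oc3ccc(NC(=O)c4cn(-c5ccccc5)nn4)cc3F)ccnc2cc1OCCCN1CCCCC1` sits, in a functional assay on HT-29 cells (Homo sapiens) for cytotoxicity, read by MTT assay, with a stated time of 72 h (on this read-out higher numbers stand for weaker inhibition and lower numbers for stronger inhibition), at 180 nM. Among the compounds with values here, compound 1 `COc1cc2c(Oc3ccc(NC(=O)c4cn(-c5ccccc5)nn4)cc3F)ccnc2cc1OCCCN1CCCC1` gives 180 nM, and the two share the lowest numbers of the three measured so far; no change at the digits printed from compound 1 to compound 3 (within the scatter). Compound 2 `COc1cc2c(Oc3ccc(NC(=O)c4cn(-c5c(C)cccc5C)nn4)cc3F)ccnc2cc1OCCCN1CCCC1` gives 2240 nM, and a 12-fold higher number from compound 1 to compound 2 (1.09 log units; beyond the scatter).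

Compound 4 `COc1cc2c(Oc3ccc(NC(=O)c4cn(-c5ccccc5F)nn4)cc3F)ccnc2cc1OCCCN1CCCCC1` differs from compound 3 in one place: fluoro in place of hydrogen on an aromatic carbon. The phenyl ring on the triazole nitrogen is the same ring that was changed in going from compound 1 to compound 2, where two methyl groups ortho to the large group brought a large weakening. A single fluorine on that ring is a smaller change than two methyl groups, so the step is expected to be smaller than that one and could fall within the scatter. On that basis compound 4 is estimated at 320 nM, within 120 nM to 900 nM, which means an expected 1.8-fold higher number from compound 3 to compound 4 (0.25 log units; within the scatter).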

Compound 4, half-maximal inhibitory concentration: 290 nM
Beside the measured number, compound 4's estimate is 1.1-fold (0.04 log units) above it; the range from low to high includes it.
By their numbers in this assay, from the lowest: compounds 1, 3 and 4 (each within the scatter of the next); then compound 2.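

In this assay the change from phenyl to 2-fluorophenyl gives a 1.6-fold higher number from compound 3 to compound 4 (0.21 log units; within the scatter) so a single fluoro on this aromatic carbon, ortho to a large group, does not move the number beyond the scatter. Within the data shown here, until now the only change on this ring was the one to 2,6-dimethylphenyl, which gave a 12-fold higher number from compound 1 to compound 2 (1.09 log units; beyond the scatter) and could have suggested that any substituent there weakens inhibition. Compound 4 shows that this does not hold for every group, although one fluoro says little about larger ones.

From the compounds shown here alone, whether 2-methylphenyl or 2-chlorophenyl would stay as close to phenyl as 2-fluorophenyl does, or move towards 2,6-dimethylphenyl, remains open. Nothing available explains the size of either step on this ring.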